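A Formyl for Methyl Swap in Ovarian Cells

A few compounds are considered here, and "the series" means these few. Any claim that something is new, unique, unknown or untested is made for them only; others in the source may bear on it.

In a functional assay on SK-OV-3 cells (Homo sapiens) for inhibition, read by CCK-8 assay, with a stated time of 70 h (a higher number here means a weaker inhibitor, a lower number a stronger inhibitor), compound 1 (`Nc1ccccc1COc1ccc(OCCOCCNC2CCCC2)cc1`) gives 14000 nM, compound 2 (`Nc1ccc(COc2ccc(OCCOCCNC3CCCC3)cc2)cc1`) gives 31700 nM, and compound 3 (`Cc1ccc(COc2ccc(OCCOCCNC3CCCC3)cc2)cc1`) gives 17200 nM. Compound 3 stands within the scatter of both others, as a 1.2-fold higher number from compound 1 to compound 3 (0.09 log units; within the scatter) and a 1.8-fold lower number from compound 2 to compound 3 (0.27 log units; within the scatter) show. Compound 4 (`O=Cc1ccc(COc2ccc(OCCOCCNC3CCCC3)cc2)cc1`) has formyl in place of methyl on an aromatic carbon. Going by the values given here, no formyl compound has been measured. Among the compounds with values here, the closest measured exchange, a 1.8-fold lower number from compound 2 to compound 3 (0.27 log units; within the scatter), stayed within the scatter, and the only step beyond it, a 2.3-fold higher number from compound 1 to compound 2 (0.35 log units; beyond the scatter), was modest. No change beyond the scatter is therefore expected, and the expected step is a 1.0-fold higher number from compound 3 to compound 4 (0.02 log units; within the scatter). For compound 4 the estimate is 18000 nM, with an expected range of 8000 nM to 40000 nM.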

Compound 4, half-maximal inhibitory concentration: 45000 nM
Estimate against measurement, compound 4: 2.5-fold (0.40 log units) below; measured number above the stated range.
By their numbers in this assay, from the lowest: compounds 1, 3, 2 and 4 (each within the scatter of the next, the first and the last beyond it).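

In this assay, the aromatic carbon para to a large group gave its first step beyond the scatter when formyl replaced methyl (a 2.6-fold higher number from compound 3 to compound 4 (0.42 log units; beyond the scatter)). Formyl does not separate from amino at that carbon (a 1.4-fold higher number from compound 2 to compound 4 (0.15 log units; within the scatter)), so this exchange parts it from methyl alone, while the gap to the 2-aminophenyl compound is also beyond the scatter (a 3.2-fold higher number from compound 1 to compound 4 (0.51 log units; beyond the scatter)). Nothing available on these compounds accounts for the shift. As far as these compounds go, what a carboxylic acid or a hydroxymethyl at this carbon would give remains open, as does 2-formylphenyl in place of 4-formylphenyl.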